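Phenyl in place of pyridyl on the thioether chain

The source may hold more compounds than are shown below. What is called first, only, known or untested is meant among the compounds shown, and "the series" means these compounds.

Among the compounds with values here, compound 3 `CC(Sc1nc2c(cnn2C)c(=O)n1-c1ccccc1)c1cccnc1` gives 95 nM in an assay on isolated protein for inhibition of Retinaldehyde dehydrogenase 3 (Homo sapiens) (on this read-out lower numbers stand for stronger inhibition and higher numbers for weaker inhibition), and stands second highest of the three numbers measured so far, nearest to compound 1 `CC(Sc1nc2c(cnn2C)c(=O)n1-c1ccccc1)c1ccccn1` with 89 nM and furthest from compound 2 `CC(Sc1nc2c(cnn2C)c(=O)n1-c1ccccc1)c1cccc(F)c1` with 128 nM. Compound 4 `C[C@H](Sc1nc2c(cnn2C)c(=O)n1-c1ccccc1)c1ccccc1` differs from compound 3 by 1-phenylethyl in place of 1-(pyridin-3-yl)ethyl on a sulfur. The measured steps that bear on this exchange are a 1.4-fold higher number from compound 1 to compound 2 (0.16 log units; within the scatter), a 1.3-fold lower number from compound 2 to compound 3 (0.13 log units; within the scatter) and a 1.1-fold higher number from compound 1 to compound 3 (0.03 log units; within the scatter), each of them within the scatter. Exchanging one six-membered aromatic ring for another at this position has so far moved the numbers little, so no step beyond the scatter is expected in this assay for compound 4. Compound 4 is therefore estimated at 110 nM, within a range of 55 nM to 220 nM, which means a step of a 1.2-fold higher number from compound 3 to compound 4 (0.06 log units; within the scatter).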

Compound 4, half-maximal inhibitory concentration: 1640 nM
For compound 4 the middle estimate is 15-fold (1.17 log units) below the measured one; the whole stated range lies below it.
By their numbers in this assay, from the lowest: compounds 1, 3 and 2 (each within the scatter of the next); then compound 4.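

At this position the unsubstituted 1-phenylethyl group does not behave like the other rings: in this assay there is a 17-fold higher number from compound 3 to compound 4 (1.24 log units; beyond the scatter) and an 18-fold higher number from compound 1 to compound 4 (1.27 log units; beyond the scatter) as well as a 13-fold higher number from compound 2 to compound 4 (1.11 log units; beyond the scatter). The 1-(3-fluorophenyl)ethyl group of compound 2 also has a carbon-only ring, yet it shows no such loss, so the absence of ring nitrogen alone does not account for it. Nothing at hand explains this step.

Going by these compounds, compound 4 alone carries a defined stereocentre, so the effects of ring and stereocentre cannot be separated, and its mirror-image form remains open. On these data alone, whether an amine or methoxy group on the phenyl ring would restore the number also remains open.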